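The compounds below may be only part of what the source reports. "The series", "measured", "known", "first", "only" and "open" are said of these compounds alone.

Measured so far in an assay on isolated protein for inhibition of interferon-induced, double-stranded RNA-activated protein kinase (Homo sapiens), read by luminescence, with a stated time of 10 min; a higher number here means a weaker inhibitor, a lower number a stronger inhibitor:
Compound 1 `COCCCNc1nccc(-c2c(C)[nH]c3ccccc23)n1` gives 1500 nM.
Compound 2 `Cc1[nH]c2ccc(Cl)cc2c1-c1ccnc(NCc2cccnc2)n1` gives 48000 nM.
Compound 3 `Cc1[nH]c2ccc(Cl)cc2c1-c1ccnc(N2CCCC2)n1` gives > 100000 nM, which is a limit of the assay and not a number.

Compound 3 therefore stands at the weak end of what has been measured, at the limit of > 100000 nM in this assay, at which 1 of the 3 values shown sits. Compound 4 `COCCCNc1nccc(-c2c(C)[nH]c3ccc(Cl)cc23)n1` differs from compound 3 by (3-methoxypropyl)amino in place of pyrrolidin-1-yl on an aromatic carbon. Within the data shown here, the one measured step at this position is an at least 2.0-fold higher number from compound 2 to compound 3 (0.31 log units; beyond the scatter), where pyrrolidin-1-yl replaced an amino group and inhibition became weaker. Compound 4 brings an amino group back, and compound 1, which carries the same (3-methoxypropyl)amino group, gives 1500 nM in this assay. An improvement of an at least 50-fold lower number from compound 3 to compound 4 (1.69 log units; beyond the scatter) is thus expected. Compound 4 is estimated at 2000 nM, with a range from 500 nM to 10000 nM.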

Compound 4, half-maximal inhibitory concentration: 3000 nM
Compound 4: the middle estimate sits 1.5-fold (0.18 log units) below what was measured; measured number inside the range.
By their numbers in this assay, from the lowest: compounds 1 and 4 (each within the scatter of the next); then compound 2. At a limit, above all of these: compound 3.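

Replacing the pyrrolidin-1-yl ring with the open (3-methoxypropyl)amino chain gives an at least 33-fold lower number from compound 3 to compound 4 (1.52 log units; beyond the scatter), so the group at this position has a large influence on inhibition. The end of the chain also counts: 2-methoxyethyl in place of pyridin-3-yl gives a 16-fold lower number from compound 2 to compound 4 (1.20 log units; beyond the scatter), while chloro in place of hydrogen on the core gives a 2.0-fold higher number from compound 1 to compound 4 (0.30 log units; within the scatter), a change the scatter cannot separate from none.

On these data alone, it remains open whether the chain's oxygen or the amino hydrogen matters more. A plain butylamino chain and a tertiary amine keeping the methoxypropyl chain would test these separately.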